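From methyl to chloro on a shared core

The compounds below may be only part of what the source reports. "The series", "measured", "known", "first", "only" and "open" are said of these compounds alone.

Measured so far in a functional assay on NSCLC cells (Homo sapiens) for antiproliferative activity; on this read-out lower numbers stand for stronger inhibition of growth and higher numbers for weaker inhibition of growth:
- compound 1 `Cc1cn2c(/C=N/NC(=N)N)c(-c3ccncc3)nc2s1`: 33100 nM
- compound 2 `Cc1cn2c(/C=N/NC(=N)N)c(-c3cccnc3)nc2s1`: 36300 nM

Among the measured compounds shown here, only two compounds have been measured, and compound 2 stands level with compound 1, with no real difference between them. For the measured compounds named here, the single measured step is a 1.1-fold higher number from compound 1 to compound 2 (0.04 log units; within the scatter). Compound 3 `N=C(N)N/N=C/c1c(-c2cccnc2)nc2sc(Cl)cn12` keeps the pyridin-3-yl group of compound 2 and differs at another place: chloro in place of methyl on an aromatic carbon. The measured step concerns the pyridinyl group, so it bears on this change only indirectly. Going by the values given here, no measured compound carries chloro, and the data favour no direction in this assay. A step within the scatter is therefore the sensible expectation, though with wide uncertainty. The expected step is a 1.2-fold lower number from compound 2 to compound 3 (0.08 log units; within the scatter). The estimate for compound 3 is 30000 nM, with an expected range from 10000 nM to 70000 nM.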

Compound 3, concentration for total growth inhibition: 41700 nM
Estimate against measurement, compound 3: 1.4-fold (0.14 log units) below; the range from low to high includes it.
By their numbers in this assay, from the lowest: compounds 1, 2 and 3 (each within the scatter of the next).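

The position next to the ring sulfur now has its first reading: in this assay there is a 1.1-fold higher number from compound 2 to compound 3 (0.06 log units; within the scatter) on putting chloro in place of methyl, with the pyridin-3-yl group held fixed. On this read-out, then, methyl and chloro cannot be told apart at this position, so this change on the aromatic carbon leaves growth inhibition effectively as it was. No measured property is at hand to account for this result.

On these data alone, whether a different kind of group at this position, such as an amine, a carboxylic acid or a longer alkyl chain, would move the number beyond the scatter remains open. As far as these compounds go, it is also open whether chloro would behave the same way alongside the pyridin-4-yl group of compound 1.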